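The source may hold more compounds than are shown below. What is called first, only, known or untested is meant among the compounds shown, and "the series" means these compounds.

Working notes on the series. Compound 1 `Clc1ccc(-c2n[nH]cc2N2CCCNCC2)cc1` and compound 2 `Fc1ccc(-c2n[nH]cc2N2CCCNCC2)cc1` share one core; compound 3 `Clc1ccc(-c2n[nH]cc2N2CCNCC2)cc1` and compound 4 `Fc1ccc(-c2n[nH]cc2N2CCNCC2)cc1` share another. The difference between the two cores is not broken down here.

In an assay on isolated protein for binding affinity to 5-hydroxytryptamine receptor 4 (Homo sapiens) (on this read-out higher numbers stand for weaker inhibition and lower numbers for stronger inhibition), compound 1 gives only a limit of the assay, > 10000 nM, and not a number. In this assay compound 2 likewise gives only a limit, > 10000 nM. In this assay compound 3 also gives only a limit, > 10000 nM.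

The change from compound 1 to compound 2 is fluoro in place of chloro on an aromatic carbon. The accompanying step, a step that the two limits leave unreadable from compound 1 to compound 2, cannot be sized because of the limit of > 10000 nM in this assay, at which 3 of the 3 values shown sit.

The change from compound 3 to compound 4 is the same change, (fluoro in place of chloro on an aromatic carbon), and the place is the same in both pairs. Among the compounds with values here, nothing measured so far separates the two members of either pair.

For compound 4 the expectation is that the same change on the second core again leaves the value at the limit, since compound 3 itself gives only a limit, > 10000 nM. Within the data shown here, the step expected here is a step that the limit leaves unreadable from compound 3 to compound 4, set beside the earlier unreadable one, and rests on the fact that every value in this assay so far sits at the limit. Compound 4 is accordingly estimated at 20000 nM, with a range from 8000 nM to 60000 nM, and most likely to be reported only as a limit.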

Compound 4, inhibition constant: > 10000 nM
Compound 4: a limit, no number; the forecaster's own chance of this, stated with the estimate: 85%; the middle value is on the limit's open side.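

In this assay compound 4 gives only a limit, > 10000 nM, and not a number. No step can be read from compound 3 to compound 4, because both compounds rest at the same limit: the limit of > 10000 nM in this assay, at which 4 of the 4 values shown sit.

The compounds shown leave open whether fluoro and chloro differ in affinity on either core, and whether the two cores differ at all.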